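Dihydropyridine series: compound 3 to compound 4

The source may hold more compounds than are shown below. What is called first, only, known or untested is meant among the compounds shown, and "the series" means these compounds.

Among the compounds with values here, compound 3 `COC(=O)C1=C(C)N=C(C)/C(=C(\O)OC)C1c1ccc(Cl)cc1Cl` gives 640 nM in a functional assay (muscle tissue) with Cavia porcellus as the target (a higher number here means that more compound is needed for the effect, a lower number that less compound is needed), the lowest number of the three measured so far. Compound 1 `COC(=O)C1=C(C)N=C(C)/C(=C(\O)OC)C1c1ccc(Cl)cc1` gives 8130 nM and compound 2 `COC(=O)C1=C(C)N=C(C)/C(=C(\O)OC)C1c1ccccc1N` gives 39800 nM; the step of a 13-fold lower number from compound 1 to compound 3 (1.10 log units; beyond the scatter) and the step of a 62-fold lower number from compound 2 to compound 3 (1.79 log units; beyond the scatter) set compound 3 clearly apart. Compound 4 `COC(=O)C1=C(C)N=C(C)/C(=C(\O)OC)C1c1ccc(Br)cc1` differs from compound 3 by 4-bromophenyl in place of 2,4-dichlorophenyl on a saturated ring carbon. Going by these compounds, the step that bears most on this is a 13-fold lower number from compound 1 to compound 3 (1.10 log units; beyond the scatter), since compound 4, like compound 1, carries a single halogen in the 4-position and none in the 2-position; bromine against chlorine there is untested. A return toward compound 1 is therefore expected, an 11-fold higher number from compound 3 to compound 4 (1.04 log units; beyond the scatter), and compound 4 is estimated at 7000 nM, within 2000 nM to 25000 nM.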

Compound 4, half-maximal effective concentration: 540 nM
For compound 4 the middle estimate is 13-fold (1.11 log units) above the measured one; measured number below the stated range.
By their numbers in this assay, from the lowest: compounds 4 and 3 (each within the scatter of the next); then compound 1; then compound 2.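

Swapping the chloro of the 4-chlorophenyl group for bromo alone gives a 15-fold lower number from compound 1 to compound 4 (1.18 log units; beyond the scatter), so the identity of this single halogen on the aromatic carbon matters strongly. The 4-bromophenyl group sits level with the 2,4-dichlorophenyl group, a 1.2-fold lower number from compound 3 to compound 4 (0.07 log units; within the scatter), and far from the 2-aminophenyl group, a 74-fold lower number from compound 2 to compound 4 (1.87 log units; beyond the scatter), so a second chloro is not needed to reach this range. No evidence on why bromo and chloro differ here is available.

Still open, going by these compounds, is whether iodo, methyl or trifluoromethyl in place of the bromo extends the step. Also open, on these data alone, is whether a chloro added to the 4-bromophenyl group, as in the 2,4-dichlorophenyl group, lowers the number further.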